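Moving one fluorine around a tetrafluorophenyl ring

The compounds below may be only part of what the source reports. "The series", "measured", "known", "first", "only" and "open" are said of these compounds alone.

Compound 1 `Cc1c(CCCC(=O)O)c2cccc(/C=C/c3ccc(OCCCCc4c(F)c(F)cc(F)c4F)cc3)c2n1CC(=O)O` has the lowest number of the three compounds measured in a physicochemical assay for permeability, using PAMPA, with a stated time of 4 h, at pH 7.4, tested at 50 uM; on this read-out higher numbers stand for higher permeability and lower numbers for lower permeability: compound 1 gives 0.5 10^-6 cm/s. Compound 2 `Cc1c(F)cccc1CCCCOc1ccc(C#Cc2cccc3c(CCCC(=O)O)c(C)n(CCCC(=O)O)c23)cc1` gives 12.4 10^-6 cm/s and compound 3 `Cc1c(Cl)cccc1CCCCOc1ccc(C#Cc2cccc3c(CCC(=O)O)c(C)n(CCCCC(=O)O)c23)cc1` gives 4.6 10^-6 cm/s, both well beyond the usual scatter above compound 1. Compound 4 `Cc1c(CCCC(=O)O)c2cccc(/C=C/c3ccc(OCCCCc4cc(F)c(F)c(F)c4F)cc3)c2n1CC(=O)O` has not yet been measured. It differs from compound 1 only in how the same atoms are joined: 2,3,4,5-tetrafluorophenyl in place of 2,3,5,6-tetrafluorophenyl on a saturated chain carbon, four bonds along the chain from an oxygen on an aromatic ring. Among the compounds with values here, no measured pair shows what such a rearrangement does here, so the expectation rests on the fact that nothing is added or removed. The step of a 1.2-fold higher number from compound 1 to compound 4 (0.08 log units; within the scatter) is expected to stay within the usual scatter, with no clear direction. Compound 4 is therefore estimated at 0.6 10^-6 cm/s, with a range from 0.25 10^-6 cm/s to 1.4 10^-6 cm/s.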

Compound 4, apparent permeability: 0.3 10^-6 cm/s
The estimate for compound 4 lay 2.0-fold (0.30 log units) above the measured number; the measured number falls inside the stated range.
By their numbers in this assay, from the lowest: compounds 4 and 1 (each within the scatter of the next); then compound 3; then compound 2.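

Moving one fluorine, so that 2,3,4,5-tetrafluorophenyl replaces 2,3,5,6-tetrafluorophenyl on a saturated chain carbon, gives a 1.7-fold lower number from compound 1 to compound 4 (0.22 log units; within the scatter) in this assay. Within the data shown here, this is the first pair here that differs in only one place, and it shows that this rearrangement of the same atoms does not separate the two compounds. No measurement is available that could explain the result. The compounds shown leave open whether a plain phenyl ring, a ring with fewer fluorines, or an amine at this place would shift the number beyond the scatter.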